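From Trifluoromethyl to Fluoro: Estimating Compound 3

The source may report more compounds than this note shows. Statements on the series, on what has been measured and on what is new or still open speak of the compounds shown alone.

Compound 1 `CCn1nc(C)c2c1CCN([C@@H](C(=O)NC)c1ccccc1)[C@H]2CCc1ccc(C(C)C)cc1`: 161 nM
Compound 2 `CCn1nc(C)c2c1CCN(C(C(=O)NC)c1ccccc1)C2CCc1cccc(C(F)(F)F)c1`: 358 nM

In a functional assay on CHO cells for antagonist activity at Orexin/Hypocretin receptor type 1 (Homo sapiens), read by FLIPR and calcium flux (a higher number here means a weaker inhibitor, a lower number a stronger inhibitor), compound 2 gives 358 nM, the higher of the two numbers seen so far. Compound 1 gives 161 nM, a gap that lies beyond the usual scatter. Compound 3 `CCn1nc(C)c2c1CCN(C(C(=O)NC)c1ccccc1)C2CCc1cccc(F)c1` differs from compound 2 by fluoro in place of trifluoromethyl on an aromatic carbon. Among the compounds with values here, no measured pair shows this same change, so nothing here tells how large a step it brings. A modest weakening, only a little beyond the scatter, is expected for a 1.8-fold higher number from compound 2 to compound 3 (0.26 log units; within the scatter). Compound 3 is therefore estimated at 650 nM, with a range from 250 nM to 1700 nM.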

Compound 3, half-maximal inhibitory concentration: 402 nM
For compound 3 the middle estimate is 1.6-fold (0.21 log units) above the measured one; low and high end bracket the measured number.
By their numbers in this assay, from the lowest: compound 1; then compounds 2 and 3 (each within the scatter of the next).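

Swapping trifluoromethyl, of 4 heavy atoms, for fluoro, of 1 heavy atom, on this aromatic carbon gives a 1.1-fold higher number from compound 2 to compound 3 (0.05 log units; within the scatter) in this assay and leaves the two compounds indistinguishable. Within the data shown here, this position therefore accepts both groups alike in this read-out, which the earlier compounds could not show. Nothing shown accounts for this result.

The compounds leave open whether an amine, a carboxylic acid or a plain hydrogen on this carbon would fare the same way. Also open, as far as these compounds go, is whether this swap would give so small a step on another compound.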